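The compounds below may be only part of what the source reports. "The series", "measured", "known", "first", "only" and "open" are said of these compounds alone.

In a functional assay (aorta) with Rattus norvegicus as the target (a higher number here means that more compound is needed for the effect, a lower number that less compound is needed), compound 1 `COc1ccc(-c2nc(N=C(N)N)sc2-c2ccc(OC)cc2)cc1` gives 2 uM. Compound 2 `COc1ccc(-c2nc(/N=C(\N)NC3CCCCC3)sc2-c2ccc(OC)cc2)cc1` gives > 100 uM, which is a limit of the assay and not a number. Compound 3 `CCN(CC)C(=O)c1nc(-c2ccc(OC)cc2)c(-c2ccc(OC)cc2)s1` gives 14 uM, the higher of the two actual numbers. Its nearest neighbour is compound 1, and the move between them is a 7.0-fold higher number from compound 1 to compound 3 (0.85 log units; beyond the scatter). The move in the other direction along the series, an at least 7.1-fold lower number from compound 2 to compound 3 (0.85 log units; beyond the scatter), starts from a limit.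

Compound 4 `COc1ccc(-c2nc(C(=O)N3CCCCC3)sc2-c2ccc(OC)cc2)cc1` carries piperidin-1-yl in place of diethylamino on a carbonyl carbon. Within the data shown here, no measured step exchanges one group on that carbonyl carbon for another, so the evidence is only indirect. The largest change seen, an at least 50-fold higher number from compound 1 to compound 2 (1.69 log units; beyond the scatter), puts cyclohexyl in place of hydrogen on an amine nitrogen, a different place from the one altered here. The move to compound 3, a 7.0-fold higher number from compound 1 to compound 3 (0.85 log units; beyond the scatter), replaces the whole group on an aromatic carbon and is a far larger edit than this one. In this assay, therefore, no shift beyond the scatter is expected, though the uncertainty is wide in both directions. The expected step is a 1.1-fold higher number from compound 3 to compound 4 (0.03 log units; within the scatter). For compound 4 the estimated value is 15 uM, with an expected range from 5 uM to 50 uM.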

Compound 4, concentration for half-maximal effect: 11 uM
For compound 4 the middle estimate is 1.4-fold (0.13 log units) above the measured one; the range from low to high includes it.
By their numbers in this assay, from the lowest: compound 1; then compounds 4 and 3 (each within the scatter of the next). At a limit, above all of these: compound 2.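

Among these compounds, this is the first exchange at the carbonyl carbon itself, and in this assay piperidin-1-yl in place of diethylamino gives a 1.3-fold lower number from compound 3 to compound 4 (0.10 log units; within the scatter), so at this place the open and the ring form of the group cannot be told apart. The gap to compound 1 survives the exchange, since a 5.5-fold higher number from compound 1 to compound 4 (0.74 log units; beyond the scatter) lies beyond the scatter just as the earlier step to compound 3 does, which means that this gap is now seen with two different groups on the carbonyl carbon and not with diethylamino alone. The remaining step, an at least 9.0-fold lower number from compound 2 to compound 4 (0.95 log units; beyond the scatter), starts from a limit and not from a number, so it gives only a minimum size: the limit of > 100 uM in this assay, at which 1 of the 4 values shown sits.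

Only diethylamino and piperidin-1-yl are shown on this carbonyl carbon, so it remains open whether a smaller ring such as pyrrolidine, a ring such as morpholine or a secondary amide that keeps the amide hydrogen would stay equally close to compound 3. The compounds shown also leave open whether any group on the carbonyl carbon could close the gap to compound 1.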